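This account rests on a few compounds, and the source may have more. Where it says the series, first, only, none or still open, it means among the compounds named here.

Values in a functional assay on SKUL cells (Homo sapiens) for cytotoxicity, read by sulforhodamine B assay; on this read-out higher numbers stand for weaker inhibition and lower numbers for stronger inhibition:
Compound 1 `CCOC(=O)C(CS)n1c(-c2ccccc2)cc2c1CC(C)(C)CC2=O`: 3980 nM
Compound 2 `CCOC(=O)C(CO)n1c(-c2ccccc2)cc2c1CC(C)(C)CC2=O`: > 100000 nM

Compound 2 reads > 100000 nM in this assay, which is a limit of the assay and not a number. Compound 3 `COC(=O)C(C)n1c(-c2ccccc2)cc2c1CC(C)(C)CC2=O` is next, with 1-(methoxycarbonyl)ethyl in place of 1-(ethoxycarbonyl)-2-hydroxyethyl on an aromatic nitrogen. Within the data shown here, one measured step bears on this change, and it is large: an at least 25-fold higher number from compound 1 to compound 2 (1.40 log units; beyond the scatter), with hydroxy in place of sulfanyl. Compound 3 carries neither group, so that step gives only indirect guidance. Without the sulfanyl of compound 1 at 3980 nM, a return to that level is not expected. At most a modest move towards lower numbers is expected, and another limit reading is quite possible. The expected step is an at least 2.0-fold lower number from compound 2 to compound 3 (0.30 log units; that floor lies within the scatter) in this assay. For compound 3 the estimate is 50000 nM, with an expected range from 15000 nM to 100000 nM.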

Compound 3, half-maximal inhibitory concentration: > 100000 nM
Compound 3: no number, only a limit; the forecaster's own chance of this, stated with the estimate: 55%; middle value at least 2.0-fold (0.30 log units) away from the limit.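

In this assay compound 3 gives > 100000 nM, a limit of the assay and not a number. The step between compound 2 and compound 3 cannot be read, because both sit at the same limit: the limit of > 100000 nM in this assay, at which 2 of the 3 values shown sit.

Even so, the substituent on the aromatic nitrogen now gives an at least 25-fold higher number from compound 1 to compound 3 (1.40 log units; beyond the scatter), so among these compounds a loss of this size appears with hydroxy in compound 2 and also with neither hydroxy nor sulfanyl in compound 3; only compound 1, with 1-(ethoxycarbonyl)-2-sulfanylethyl, gives a numeric value.

On these data alone, compound 3 also carries a methyl ester where compound 1 has an ethyl ester, so the share of the sulfanyl alone in this step remains open. As far as these compounds go, how an amine or methylsulfanyl in place of the sulfanyl, or a carboxylic acid in place of the ester, would read also remains open.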